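The source may hold more compounds than are shown below. What is called first, only, known or untested is meant among the compounds shown, and "the series" means these compounds.

Measured so far in an assay on CHO cells for displacement of a labelled ligand from adenosine receptor A3 (Homo sapiens), read by scintillation counting, tested at 10 uM; on this read-out lower numbers stand for less inhibition and higher numbers for more inhibition at the one concentration tested (going by the name of the read-out):

compound 1 `CC(C)(C)Cc1csc(N)c1C(=O)c1ccc(Cl)cc1` gives 5%
compound 2 `Cc1sc(N)c(C(=O)c2ccc(Cl)cc2)c1-c1ccccc1` gives 1%
compound 3 `CC(C)(C)Cc1c(/C=C/c2ccc(Cl)cc2)sc(N)c1C(=O)c1ccc(Cl)cc1` gives 11%

On these numbers compound 3 is not separated from the others: the step from compound 1 a number 6 percentage points higher from compound 1 to compound 3 (within the scatter) is within the scatter, and the value of compound 2 also lies within the scatter of that of compound 3. All three sit at low inhibition in this assay.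

Compound 4 `CC(C)c1ccc(-c2sc(N)c(C(=O)c3ccc(Cl)cc3)c2CC(C)(C)C)cc1` is the next member. The change from compound 3 is 4-isopropylphenyl in place of 2-(4-chlorophenyl)ethenyl on an aromatic carbon. Among the measured compounds shown here, the only measured step that touches this position is the one that introduced the 2-(4-chlorophenyl)ethenyl group, a number 6 percentage points higher from compound 1 to compound 3 (within the scatter), within the scatter. For the measured compounds named here, no measured pair shows a 4-isopropylphenyl group at any position, so there is no step to lean on for the incoming group; compound 2, the only other compound with a substituent at this position, gives 1%. The expected step from compound 3 to compound 4 in this assay is therefore none beyond the scatter, a number 3 percentage points lower from compound 3 to compound 4 (within the scatter). Compound 4 is estimated at 8%, between 0% and 20%.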

Compound 4, a percentage reported as inhibition, at one concentration (the size of the read-out at that concentration, not a potency): 1%
Compound 4: the middle estimate sits 7 percentage points above what was measured; the range from low to high includes it.
By their numbers in this assay, from the lowest: compounds 2, 4, 1 and 3 (each within the scatter of the next).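

At this position, the aromatic carbon next to the ring sulfur, this assay shows 4-isopropylphenyl in place of 2-(4-chlorophenyl)ethenyl as a number 10 percentage points lower from compound 3 to compound 4 (within the scatter). Set against hydrogen, the same group gives a number 4 percentage points lower from compound 1 to compound 4 (within the scatter), so a phenyl ring bearing isopropyl, with no chlorine and no double bond outside aromatic rings, is separated from neither hydrogen nor 2-(4-chlorophenyl)ethenyl, and this position has so far shown no change beyond the scatter. No supporting evidence bears on this result.

The compounds shown leave open whether an amine or a carboxylic acid at this position would give a step beyond the scatter. They also leave open whether a longer chain in place of the neopentyl group would alter these low readings.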